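The source may hold more compounds than are shown below. What is called first, only, known or untested is meant among the compounds shown, and "the series" means these compounds.

Measured so far in a functional assay on HCT-116 cells (Homo sapiens) for inhibition, read by MTT assay, with a stated time of 72 h; on this read-out lower numbers stand for stronger inhibition and higher numbers for weaker inhibition:
- compound 1 `O=C(NO)c1ccc(CNCc2nc(-c3ccc([N+](=O)[O-])cc3)no2)cc1`, 21900 nM
- compound 2 `O=C(NO)c1ccc(CNCc2nc(-c3ccc(F)cc3)no2)cc1`, 17800 nM

For the measured compounds named here, compound 2 gives the lower of the two numbers in this assay, yet it lies within the scatter of compound 1: the single measured step, a 1.2-fold lower number from compound 1 to compound 2 (0.09 log units; within the scatter), does not separate the two.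

Compound 3 `O=C(NO)c1ccc(CNCc2nc(-c3cccs3)no2)cc1` is not yet measured. It differs from compound 2 as follows: thiophen-2-yl in place of 4-fluorophenyl on an aromatic carbon. Going by the values given here, the only step on record, a 1.2-fold lower number from compound 1 to compound 2 (0.09 log units; within the scatter), changes the group on the same aromatic ring and was within the scatter, so it bears on the new step only loosely and gives no reason to expect a shift in either direction. On that basis the change from compound 2 to compound 3 is expected to produce no step beyond the scatter, a 1.0-fold higher number from compound 2 to compound 3 (0.00 log units; within the scatter). Compound 3 is therefore estimated at 18000 nM in this assay, within a range of 6000 nM to 55000 nM.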

Compound 3, half-maximal inhibitory concentration: > 100000 nM
Compound 3: a limit, no number (the forecaster's own chance of this, stated with the estimate: 10%); middle value at least 5.5-fold (0.74 log units) from the limit.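

In this assay compound 3 stands at a limit of the assay, not at a number: the limit of > 100000 nM in this assay, at which 1 of the 3 values shown sits. At this aromatic carbon, between two ring nitrogen atoms, thiophen-2-yl in place of 4-fluorophenyl gives an at least 5.6-fold higher number from compound 2 to compound 3 (0.74 log units; beyond the scatter), and thiophen-2-yl in place of 4-nitrophenyl gives an at least 4.5-fold higher number from compound 1 to compound 3 (0.65 log units; beyond the scatter). Among these three compounds, then, exchanging the whole aromatic ring at this position moves the read-out beyond the scatter, whereas exchanging only the group on the phenyl ring gave a 1.2-fold lower number from compound 1 to compound 2 (0.09 log units; within the scatter).

Going by these compounds, how large the true step is stays open, since the read-out for compound 3 is only a limit. On these data alone, it is also open whether the five-membered ring or its sulfur carries the change, which a furan-2-yl or an unsubstituted phenyl group at this position could separate.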